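The source may report more compounds than this note shows. Statements on the series, on what has been measured and on what is new or still open speak of the compounds shown alone.

Measured in a functional assay on MGC-803 cells (Homo sapiens) for antiproliferative activity, read by MTT assay, with a stated time of 72 h; on this read-out higher numbers stand for weaker inhibition and lower numbers for stronger inhibition:
compound 1 `Cc1ccc(-c2nc(CNc3ccc(C(=O)NO)cc3)n(-c3ccccc3)n2)cc1`: > 20000 nM
compound 2 `O=C(NO)c1ccc(NCc2nc(-c3cccc(Cl)c3)nn2-c2ccccc2)cc1`: 5760 nM
compound 3 `O=C(NO)c1ccc(NCc2nc(-c3ccc(F)cc3)nn2-c2ccccc2)cc1`: 8960 nM

The entry for compound 1, > 20000 nM, is a limit and not a number.

Compound 3, at 8960 nM, cannot be separated from compound 2, at 5760 nM: the step is a 1.6-fold higher number from compound 2 to compound 3 (0.19 log units; within the scatter), within the scatter.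

Compound 4 `O=C(NO)c1ccc(NCc2nc(-c3cc4ccccc4s3)nn2-c2ccccc2)cc1` carries 1-benzothiophen-2-yl in place of 4-fluorophenyl on an aromatic carbon.

All three measured steps concern this same place. Two start from the limit and are beyond the scatter: an at least 3.4-fold lower number from compound 1 to compound 2 (0.54 log units; beyond the scatter) and an at least 2.2-fold lower number from compound 1 to compound 3 (0.34 log units; beyond the scatter). The closest guide is a 1.6-fold higher number from compound 2 to compound 3 (0.19 log units; within the scatter), which shows two different aryl groups giving values within the scatter of each other. For the measured compounds named here, no measured compound carries a group of the 1-benzothiophen-2-yl kind here, so the expectation is loose, and no step beyond the scatter is expected in this assay.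

The estimated step is a 1.5-fold lower number from compound 3 to compound 4 (0.17 log units; within the scatter).

For compound 4 the expected value is 6000 nM, with an estimated range of 1500 nM to 20000 nM.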

Compound 4, half-maximal inhibitory concentration: 6110 nM
Beside the measured number, compound 4's estimate is 1.0-fold (0.01 log units) below it; the measured number falls inside the stated range.
By their numbers in this assay, from the lowest: compounds 2, 4 and 3 (each within the scatter of the next). At a limit, above all of these: compound 1.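

In this assay, the aromatic carbon between two ring nitrogen atoms accepts 1-benzothiophen-2-yl, the only group shown with a five-membered aromatic ring holding a hetero atom, and its 9 heavy atoms leave the value within the scatter of both phenyl analogues: a 1.5-fold lower number from compound 3 to compound 4 (0.17 log units; within the scatter), and a 1.1-fold higher number from compound 2 to compound 4 (0.03 log units; within the scatter). Against this third group, 4-methylphenyl again stands apart: an at least 3.2-fold lower number from compound 1 to compound 4 (0.51 log units; beyond the scatter). The entry for compound 1 is a limit and not a number: the limit of > 20000 nM in this assay, at which 1 of the 4 values shown sits.

Only aromatic groups are shown at this place, so the effect of an amine, a carboxylic acid or a cyclohexyl group here stays open. On these data alone, the phenyl group on the ring nitrogen is the same in all four compounds, and what a change there would do is also open.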